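Adding a Hydroxy Group to the Strongest Compound So Far

The source may hold more compounds than are shown below. What is called first, only, known or untested is meant among the compounds shown, and "the series" means these compounds.

Three compounds sharing one core were tested in an assay for inhibition of Indoleamine 2,3-dioxygenase 1 (Homo sapiens), with stated times of 10 min and 60 min, tested at 10 uM; on this read-out higher numbers stand for a stronger effect at the one concentration tested and lower numbers for a weaker effect. Compound 1 `O=[N+]([O-])c1ccccc1CNc1cc(C(F)(F)F)cc2[nH]ncc12` gives 35% in this assay. Compound 2 `O=[N+]([O-])c1ccc(Cl)cc1CNc1cc(C(F)(F)F)cc2[nH]ncc12` gives 35% in this assay, and the step of no change at the digits printed from compound 1 to compound 2 (within the scatter). Compound 3 `O=[N+]([O-])c1ccccc1CNc1cc(Br)cc2[nH]ncc12` gives 67% in this assay, which is the highest of the three numbers and lies beyond the scatter above both others, reached through the step of a number 32 percentage points higher from compound 1 to compound 3 (beyond the scatter).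

Compound 4 `O=[N+]([O-])c1ccc(O)cc1CNc1cc(Br)cc2[nH]ncc12` has not yet been measured. It differs from compound 3 by hydroxy in place of hydrogen on an aromatic carbon. Among the measured compounds shown here, the one measured step that bears on a new group entering the nitro-bearing ring is no change at the digits printed from compound 1 to compound 2 (within the scatter), which stayed within the scatter. A hydroxy group is not a chloro group, so this rests on a single comparison, but on that basis the step from compound 3 to compound 4 is expected to be small, a number 2 percentage points lower from compound 3 to compound 4 (within the scatter), with no clear direction beyond the scatter. Compound 4 is therefore estimated at 65%, between 45% and 85%.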

Compound 4, a percentage reported as inhibition, at one concentration (the size of the read-out at that concentration, not a potency): 92%
For compound 4 the middle estimate is 27 percentage points below the measured one, outside the stated range (above it).
By their numbers in this assay, from the lowest: compounds 1 and 2 (each within the scatter of the next); then compound 3; then compound 4.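

In this assay, hydroxy para to a nitro group brings a number 25 percentage points higher from compound 3 to compound 4 (beyond the scatter) and so shows that this place on the six-membered aromatic ring can respond clearly to a new group. The earlier chloro change on this ring gave no change at the digits printed from compound 1 to compound 2 (within the scatter) on a core carrying trifluoromethyl instead of bromo, so the two results show that a new group on this ring need not leave the number unchanged, although they differ in more than one place and cannot separate the group from the core. Nothing shown here explains the rise in the number.

From the compounds shown here alone, it remains open whether a methoxy group or an amine at the same place would give a similar step. Going by these compounds, it is also open whether hydroxy would bring a similar rise on compound 1, which carries trifluoromethyl instead of bromo.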